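The source may report more compounds than this note shows. Statements on the series, on what has been measured and on what is new or still open speak of the compounds shown alone.

Compound 1 `COc1ccc(CCOc2ccc(-c3c(C)nc(C)c([C@H](OC(C)(C)C)C(=O)O)c3N3CCC(C)(C)CC3)cc2)cc1` was tested in a toxicity assay on MT2 cells (Homo sapiens) for cytotoxicity, read by XTT assay, with a stated time of 4 days; on this read-out higher numbers stand for lower toxicity in this test and lower numbers for higher toxicity in this test. In this assay compound 1 gives >= 33500 nM, which is a limit of the assay rather than a measured number. Compound 2 `COc1cccc(CCOc2ccc(-c3c(C)nc(C)c([C@H](OC(C)(C)C)C(=O)O)c3N3CCC(C)(C)CC3)cc2)c1` carries 3-methoxyphenyl in place of 4-methoxyphenyl on a saturated chain carbon, two bonds along the chain from an oxygen on an aromatic ring. In this assay compound 2 gives >= 33500 nM, again a limit. The step that the two limits leave unreadable from compound 1 to compound 2 therefore cannot be read. Compound 3 `Cc1nc(C)c([C@H](OC(C)(C)C)C(=O)O)c(N2CCC(C)(C)CC2)c1-c1ccc(OC2CCCC2c2ccc(F)cc2)cc1` has been measured twice in this assay, and compound 3 gives >= 32000 nM; >= 32000 nM (2 entries), both entries being limits. Among the compounds with values here, the only evidence across the set is the limit of >= 33500 nM in this assay, at which 2 of the 3 values shown sit, so every measured compound sits at a limit and no step in either direction has been seen.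

The unmeasured compound 4 `Cc1nc(CCOc2ccc(-c3c(C)nc(C)c([C@H](OC(C)(C)C)C(=O)O)c3N3CCC(C)(C)CC3)cc2)cs1` differs from compound 1 by 2-methyl-1,3-thiazol-4-yl in place of 4-methoxyphenyl on a saturated chain carbon, two bonds along the chain from an oxygen on an aromatic ring. Within the data shown here, no measured step bears on this change, and the steps that exist are all unreadable, so the expectation is that compound 4 will also stop at the limit with no shift beyond the scatter. The step from compound 1 to compound 4 is expected to be a number no higher from compound 1 to compound 4 (the limit leaves the size open). Compound 4 is therefore estimated to give 33500 nM, with an expected range from 15000 nM to 70000 nM.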

Compound 4, half-maximal cytotoxic concentration: >= 25000 nM
Compound 4 gave a limit, no number; the forecaster's own chance of this, stated with the estimate: 85%; the middle value is on the limit's open side.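

In this assay compound 4 gives >= 25000 nM, a limit of the assay and not a number. Compound 1 and compound 2 also stand at limits, so neither step to compound 4 can be read. The compounds shown leave open how toxic any of them is in this assay, and whether 2-methyl-1,3-thiazol-4-yl in place of 4-methoxyphenyl changes that at all.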